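Working notes: cytotoxicity of compounds 1 to 4

The compounds below may be only part of what the source reports. "The series", "measured", "known", "first", "only" and "open" are said of these compounds alone.

Measured compounds:
compound 1 `COc1ccc([C@H]2CC(=O)N(Cc3cccc(C#N)c3)C2)cc1OC1CCCC1` — > 10000 nM
compound 2 `COc1ccc([C@H]2CC(=O)N(Cc3cccc(N)c3)C2)cc1OC1CCCC1` — > 10000 nM
compound 3 `COc1ccc([C@H]2CC(=O)N(c3ccccc3C)C2)cc1OC1CCCC1` — > 10000 nM
not yet measured: compound 4 `COc1ccc([C@H]2CC(=O)N(c3cccc(C)c3)C2)cc1OC1CCCC1`

In a functional assay on HEK293 cells (Homo sapiens) for cytotoxicity (on this read-out higher numbers stand for lower toxicity in this test and lower numbers for higher toxicity in this test), compound 1 gives > 10000 nM, which is a limit of the assay and not a number. Compound 2 gives > 10000 nM, likewise a limit. Compound 3 gives > 10000 nM, again a limit. Compound 2 therefore stands at the limit at which all three shown values sit (the limit of > 10000 nM in this assay, at which 3 of the 3 values shown sit). Within the data shown here, the steps a step that the two limits leave unreadable from compound 1 to compound 2, a step that the two limits leave unreadable from compound 1 to compound 3 and a step that the two limits leave unreadable from compound 2 to compound 3 cannot be read from these limits, so no measured step gives a size or a direction.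

Compound 4 differs from compound 2 in one place: 3-methylphenyl in place of 3-aminobenzyl on an amide-type nitrogen in a ring. The step from compound 2 to compound 3 also exchanges the group on the same ring nitrogen, and it was unreadable. Nothing in the shown data points to a step beyond the scatter. The expectation is that compound 4 is again reported at the limit; compound 4 is estimated at 20000 nM, between 8000 nM and 60000 nM. The step from compound 2 to compound 4 is expected to be a step that the limit leaves unreadable from compound 2 to compound 4.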

Compound 4, half-maximal cytotoxic concentration: > 10000 nM
Compound 4 was reported as a limit; the forecaster's own chance of this, stated with the estimate: 85%; the middle value is on the limit's open side.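

No new step can be read between compound 4 and compound 1, compound 2 or compound 3, as each value is a limit of the assay and not a number: the limit of > 10000 nM in this assay, at which 4 of the 4 values shown sit. The compounds shown leave open whether exchanging the group on the ring nitrogen changes the read-out in this assay at all, and by how much.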